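The source may report more compounds than this note shows. Statements on the series, on what has been measured and on what is new or still open speak of the compounds shown alone.

In a functional assay on KB 3-1 cells (Homo sapiens) for inhibition, with a stated time of 72 h (a lower number here means a stronger inhibitor, a higher number a weaker inhibitor), compound 3 `CC(=O)Oc1cc2oc(-c3ccccc3)cc(=O)c2c(O)c1OCc1ccccc1` gives 18300 nM and stands second highest of the three numbers available. Compound 2 `CC(=O)Oc1cc2oc(-c3ccccc3)cc(=O)c2c(OCc2ccccc2)c1OC(C)=O` lies nearest at 12200 nM and the two values are within the scatter of each other. Compound 1 `CC(=O)Oc1c(O)cc2oc(-c3ccccc3)cc(=O)c2c1O` gives 61600 nM as the furthest value from compound 3 and that gap lies beyond the scatter.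

Compound 4 `O=c1cc(-c2ccccc2)oc2cc(O)c(OCc3ccccc3)c(O)c12` is still unmeasured and differs from compound 3 in one place: hydrogen in place of acetyl on an oxygen on an aromatic ring so that acetoxy becomes hydroxy. Within the data shown here, no measured pair isolates this change, so the data give no direct guide to its size. Compound 1 does carry hydroxy groups and sits at 61600 nM but it also lacks the benzyl group, which makes it only a weak pointer toward a higher number. No step beyond the scatter is expected, with the estimated 1.4-fold higher number from compound 3 to compound 4 (0.14 log units; within the scatter) leaning slightly upward. Compound 4 is estimated at 25000 nM (expected range 9000 nM to 70000 nM).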

Compound 4, half-maximal inhibitory concentration: 3200 nM
Beside the measured number, compound 4's estimate is 7.8-fold (0.89 log units) above it, outside the stated range (below it).
By their numbers in this assay, from the lowest: compound 4; then compounds 2 and 3 (each within the scatter of the next); then compound 1.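

In this assay, among these compounds, acetoxy to hydroxy on an oxygen on an aromatic ring, with the benzyl group kept, is the first single change to give a step beyond the scatter: a 5.7-fold lower number from compound 3 to compound 4 (0.76 log units; beyond the scatter). The other single change, benzyl in place of acetyl on an oxygen on an aromatic ring, gives a larger step, a 19-fold lower number from compound 1 to compound 4 (1.28 log units; beyond the scatter), so in these two pairs, replacing an acetyl with either hydrogen or benzyl goes with a lower number. Nothing available gives a reason for either step.

The compounds shown leave open whether this oxygen must carry a hydrogen, since a methoxy group or an amine in place of the hydroxy is not among them. They also leave open how a longer chain in place of the benzyl would read.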